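Moving the Fluoro and Methoxy Groups on the Aryl Ring

This account rests on a few compounds, and the source may have more. Where it says the series, first, only, none or still open, it means among the compounds named here.

compound 1 `CCSC[C@@](O)([C@@H](Nc1cccc2nc(C)ccc12)c1ccc(C)cc1)C(F)(F)F`: 2.51 nM
compound 2 `CCSC[C@@](O)([C@@H](Nc1cccc2nc(C)ccc12)c1ccc(F)cc1OC)C(F)(F)F`: 5.01 nM

Within the data shown here, in a functional assay on THP-1 cells (Homo sapiens) (a lower number here means a stronger inhibitor, a higher number a weaker inhibitor), compound 2 gives 5.01 nM, which stands within the scatter of compound 1, the only other measured compound. Compound 3 `CCSC[C@@](O)([C@@H](Nc1cccc2nc(C)ccc12)c1ccc(OC)c(F)c1)C(F)(F)F` has the same atoms joined differently, with 3-fluoro-4-methoxyphenyl in place of 4-fluoro-2-methoxyphenyl on a saturated chain carbon bound to a nitrogen on an aromatic ring and a saturated chain carbon. Among the measured compounds shown here, the one measured change at this place is a 2.0-fold higher number from compound 1 to compound 2 (0.30 log units; within the scatter). For the measured compounds named here, with only this small step as a guide, no clear direction is expected in this assay, and the expected change is a 1.2-fold higher number from compound 2 to compound 3 (0.08 log units; within the scatter). Compound 3 is estimated at 6 nM, with an expected range of 1.5 nM to 25 nM.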

Compound 3, half-maximal inhibitory concentration: 5.01 nM
Estimate against measurement, compound 3: 1.2-fold (0.08 log units) above; the measured number falls inside the stated range.
By their numbers in this assay, from the lowest: compounds 1, 2 and 3 (each within the scatter of the next).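

In this assay, taking 3-fluoro-4-methoxyphenyl in place of 4-fluoro-2-methoxyphenyl gives no change at the digits printed from compound 2 to compound 3 (within the scatter), so moving the fluoro and methoxy groups around the ring leaves the reading at this position unaffected. Set against the 4-methylphenyl group, the new ring gives a 2.0-fold higher number from compound 1 to compound 3 (0.30 log units; within the scatter), and the three aryl groups cannot be told apart here. Nothing available explains this tolerance. Still open, as far as these compounds go, is whether an aryl ring carrying an amine or a carboxylic acid would stay at this level, and whether any group at this position would move the number beyond the scatter.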